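The source may hold more compounds than are shown below. What is called first, only, known or untested is meant among the compounds shown, and "the series" means these compounds.

Read-out throughout is a functional assay on CAKI-1 cells (Homo sapiens) for antiproliferative activity (on this read-out higher numbers stand for weaker inhibition of growth and lower numbers for stronger inhibition of growth), for the series so far.

- Compound 1 `Cc1cc(C)c2c(O)cc(-c3cccc(F)c3)nc2n1` gives 35.5 nM
- Compound 2 `Cc1cc(C)c2c(O)cc(-c3cccc4ccccc34)nc2n1` gives 9550 nM
- Compound 3 `Cc1ccc2c(O)cc(-c3ccc4ccccc4c3)nc2n1` gives 5370 nM

Compound 1 holds the lowest number of the three, and its gaps to compound 2 and compound 3 both lie beyond the scatter. The values of those two sit within the scatter of each other. Compound 4 `Cc1cccc(-c2cc(O)c3c(C)cc(C)nc3n2)c1` is the close analogue of compound 1 still to be read. The change is methyl in place of fluoro on an aromatic carbon with methyl in place of fluoro on an aromatic carbon, meta to a large group. For the measured compounds named here, no two measured compounds differ in one place only, so the series offers no direct measure of this exchange. The expectation therefore starts from compound 1 at 35.5 nM and from the small size of the change. The expected size of the move is a 2.8-fold higher number from compound 1 to compound 4 (0.45 log units; beyond the scatter) in the direction of weaker inhibition of growth, modestly beyond the scatter. For compound 4 the estimated value is 100 nM with an expected range from 25 nM to 600 nM as the upper end.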

Compound 4, concentration for 50% growth inhibition: 56200 nM
Compound 4: the middle estimate sits 560-fold (2.75 log units) below what was measured; measured number outside the range, above it.
By their numbers in this assay, from the lowest: compound 1; then compounds 3 and 2 (each within the scatter of the next); then compound 4.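

Methyl in place of fluoro on an aromatic carbon, meta to a large group, gives a 1600-fold higher number from compound 1 to compound 4 (3.20 log units; beyond the scatter) in this assay, the first direct measure of this exchange in the series. This position is therefore far from indifferent to its substituent: one heavy atom replaced by one heavy atom, with no change in the count of hydrogen-bond donors or acceptors and no net charge, is enough for a large loss of growth inhibition. Nothing on hand accounts for the size of this step.

As far as these compounds go, whether other groups at this position, such as chloro, methoxy or an amine, stay near compound 1 or fall toward compound 4 remains open. Also open, from the compounds shown here alone, is whether the same exchange on another carbon of this ring gives a step of similar size.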